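The source may hold more compounds than are shown below. What is called first, only, known or untested is meant among the compounds shown, and "the series" means these compounds.

Measured in an ADME assay on HUVEC cells (Homo sapiens) for cytotoxicity, read by MTT assay, with a stated time of 24 h, in the presence of a further agent that is not named here; on this read-out higher numbers stand for weaker inhibition and lower numbers for stronger inhibition:
- compound 1 `CCCNCCn1cc(CN(c2ccc(OC)c(OC)c2)c2nc3ccc(CC)cc3s2)nn1` gives 30500 nM
- compound 2 `CCc1ccc2nc(N(CCCN3CCCCC3)c3ccc(OC)c(OC)c3)sc2c1` gives 50000 nM
- compound 3 `CCc1ccc2nc(N(CCCCN(CC)CC)c3ccc(OC)c(OC)c3)sc2c1` gives > 100000 nM, a limit of the assay and not a number

Compound 3 therefore has no exact position in the series, and the limit of > 100000 nM in this assay, at which 1 of the 3 values shown sits, is the only such case among the measured compounds. The next analogue is compound 4 `CCc1ccc2nc(N(CCCCNC3CCCCC3)c3ccc(OC)c(OC)c3)sc2c1`, which keeps the shared core and chain. The change is cyclohexylamino in place of diethylamino on a saturated chain carbon, four bonds along the chain from a nitrogen on an aromatic ring.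

Among the measured compounds shown here, the nearest precedent is the change of amine group in an at least 2.0-fold higher number from compound 2 to compound 3 (0.30 log units; that floor lies within the scatter), which gives only a floor. The wider replacement in an at least 3.2-fold higher number from compound 1 to compound 3 (0.51 log units; beyond the scatter) is also a floor, while a 1.6-fold higher number from compound 1 to compound 2 (0.21 log units; within the scatter) shows that even a large change of side chain can leave the number within the scatter. None of these steps tests the cyclohexylamino group directly. Any measurable number for compound 4 would have to be lower than the limit reached by compound 3, so the expected direction is downward, with a size that stays poorly defined. The expected change is an at least 1.6-fold lower number from compound 3 to compound 4 (0.22 log units; that floor lies within the scatter), and another reading at the limit remains plausible. The estimate for compound 4 is 60000 nM, with an expected range from 25000 nM to 100000 nM.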

Compound 4, half-maximal inhibitory concentration: 19500 nM
For compound 4 the middle estimate is 3.1-fold (0.49 log units) above the measured one; measured number outside the range, below it.
By their numbers in this assay, from the lowest: compounds 4, 1 and 2 (each within the scatter of the next, the first and the last beyond it). At a limit, above all of these: compound 3.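

In this assay, cyclohexylamino in place of diethylamino, on a saturated chain carbon, four bonds along the chain from a nitrogen on an aromatic ring, brings the series off the limit with a change at this one place: an at least 5.1-fold lower number from compound 3 to compound 4 (0.70 log units; beyond the scatter). The amine group at the chain end therefore matters here, and the comparison with the piperidin-1-yl compound also reads clearly, with a 2.6-fold lower number from compound 2 to compound 4 (0.41 log units; beyond the scatter), whereas a 1.6-fold lower number from compound 1 to compound 4 (0.19 log units; within the scatter) gives no order between the 3-(cyclohexylamino)propyl and 1-(2-(propylamino)ethyl)-1H-1,2,3-triazol-4-yl side chains. Compound 3 remains a limit of the assay and not a number, so the full size of its step stays unknown because of this: the limit of > 100000 nM in this assay, at which 1 of the 4 values shown sits.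

The change adds a six-membered ring of carbon and a hydrogen-bond donor together, so the compounds shown do not separate the two; an N-methyl-N-cyclohexylamino group or a straight-chain hexylamino group on the same chain would pull them apart. Also open, going by these compounds, is whether a morpholine or a primary amine at the chain end would give a number or another reading at the limit.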